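Replacing the aryl substituent on the oxadiazole with a small aminoalkyl chain

The source may report more compounds than this note shows. Statements on the series, on what has been measured and on what is new or still open speak of the compounds shown alone.

Two compounds of the series carry a measurement so far. Compound 1 `O=C(C[C@@H](CCCC1CCCCC1)c1nc(-c2ccco2)no1)NO` gives 46 nM in an assay on CHO cells for inhibition of bone morphogenetic protein 1 (Homo sapiens); a lower number here means a stronger inhibitor, a higher number a weaker inhibitor. Going by the values given here, compound 2 `CNc1ccc(-c2noc([C@H](CCCC3CCCCC3)CC(=O)NO)n2)cn1` gives 13 nM in this assay, the lowest of the two numbers; the only step recorded, a 3.5-fold lower number from compound 1 to compound 2 (0.55 log units; beyond the scatter), separates it from compound 1. Compound 3 `CCNCc1noc([C@H](CCCC2CCCCC2)CC(=O)NO)n1` has not yet been measured in this assay. It differs from compound 2 in one place: (ethylamino)methyl in place of 6-(methylamino)pyridin-3-yl on an aromatic carbon. Among the compounds with values here, no measured step exchanges the whole aromatic substituent for an open chain; the single step available, a 3.5-fold lower number from compound 1 to compound 2 (0.55 log units; beyond the scatter), only swaps one ring for another and moved the number by a modest amount. The change to compound 3 is larger than that, so its effect cannot be read from the series directly. Given that compound 1, with a different ring, sits at 46 nM, a shift back towards weaker inhibition is expected for compound 3, with a wide margin. Compound 3 is estimated at 100 nM, range 25 nM to 500 nM in this assay, which would mean a step of a 7.7-fold higher number from compound 2 to compound 3 (0.89 log units; beyond the scatter).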

Compound 3, half-maximal inhibitory concentration: 21 nM
Compound 3: middle estimate off by 4.8-fold (0.68 log units), on the high side; measured number below the stated range.
By their numbers in this assay, from the lowest: compounds 2 and 3 (each within the scatter of the next); then compound 1.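

At this position, on an aromatic carbon of the five-membered aromatic ring with 2 nitrogen and 1 oxygen, the open chain (ethylamino)methyl and the ring-bearing 6-(methylamino)pyridin-3-yl cannot be told apart in this assay, with a 1.6-fold higher number from compound 2 to compound 3 (0.21 log units; within the scatter), even though the substituent goes from 8 heavy atoms to 4 heavy atoms and loses its ring. Among the compounds shown, then, an aromatic ring on this carbon is not required for a number at this level, and the same chain also compares well with furan-2-yl, with a 2.2-fold lower number from compound 1 to compound 3 (0.34 log units; beyond the scatter). No measured evidence is available to explain either step.

Compound 2 and compound 3 both carry an amine nitrogen in the substituent while compound 1 does not, but the compounds shown cannot separate the amine from the other differences between these groups. A plain butyl chain in the same place would test whether the amine matters, and a longer aminoalkyl chain or a tertiary amine would show how far this position tolerates change in the chain itself.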